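Sulfonamide glycinamide series: cyano for trifluoromethoxy on compound 1

The source may report more compounds than this note shows. Statements on the series, on what has been measured and on what is new or still open speak of the compounds shown alone.

Measured so far:
compound 1 `CCN(CC)C(=O)CN(c1ccc(C)cc1)S(=O)(=O)c1ccc(OC(F)(F)F)cc1` — > 10000 nM
compound 2 `CCN(C(=O)CN(c1cc(N(C)C)ccc1Cl)S(=O)(=O)c1ccc(OC)c(OC)c1)c1cccc(C)n1` — 17 nM
compound 3 `CCN(CC)C(=O)CN(c1cccc(N(C)C)c1C#N)S(=O)(=O)c1ccc(OC)c(OC)c1` — > 10000 nM

In a functional assay on CHO cells for inhibition of Orexin/Hypocretin receptor type 1 (Homo sapiens), read by FLIPR and calcium flux (a lower number here means a stronger inhibitor, a higher number a weaker inhibitor), compound 1 gives only > 10000 nM, which is a limit of the assay and not a number. Compound 3 likewise reaches only > 10000 nM, again a limit. Compound 2 alone gives a number, 17 nM, in this assay. Among the three, (the limit of > 10000 nM in this assay, at which 2 of the 3 values shown sit).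

Compound 4 `CCN(CC)C(=O)CN(c1ccc(C)cc1)S(=O)(=O)c1ccc(C#N)cc1` carries cyano in place of trifluoromethoxy on an aromatic carbon. Among the measured compounds shown here, no measured step touches this change. In this assay the expected step is a number no higher from compound 1 to compound 4 (the limit leaves the size open), that is none beyond the scatter, since compound 1 sits at the limit > 10000 nM and the shared core is unchanged. Compound 4 is expected near 10000 nM, in the range 3000 nM to 30000 nM.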

Compound 4, half-maximal inhibitory concentration: > 10000 nM
Compound 4: no number, only a limit; the forecaster's own chance of this, stated with the estimate: 75%; the middle value lies on the limit itself.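

Compound 1 and compound 4 both give only a limit, so no step can be read between them: the limit of > 10000 nM in this assay, at which 3 of the 4 values shown sit.

The compounds shown leave open whether cyano and trifluoromethoxy differ at all on the core of compound 1.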